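The compounds below may be only part of what the source reports. "The series", "measured", "known", "first", "only" and "open" are said of these compounds alone.

Measured compounds:
compound 1, `Cc1cc(NC(=O)Cn2nnc(-c3ccc(Cl)c(Cl)c3)n2)n(C2CCCCC2)n1` — 1220 nM
compound 2, `Cc1cc(NC(=O)Cn2nnc(-c3ccc(F)cc3)n2)n(C2CCCCC2)n1` — 180 nM
compound 3, `Cc1cc(NC(=O)Cn2nnc(-c3ccccc3F)n2)n(C2CCCCC2)n1` — 187 nM

In an assay on HEK293 cells for activation of Kir3.1/Kir3.2 (Homo sapiens), read by thallium flux (on this read-out higher numbers stand for an effect only at larger amounts of compound and lower numbers for an effect already at smaller amounts), compound 3 stands second highest of the three numbers. Its nearest neighbour is compound 2, and the two lie within the scatter, as the step of a 1.0-fold higher number from compound 2 to compound 3 (0.02 log units; within the scatter) shows. Compound 1 is the furthest away, and the step of a 6.5-fold lower number from compound 1 to compound 3 (0.81 log units; beyond the scatter) lies beyond the scatter.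

Compound 4, `Cc1cc(NC(=O)Cn2nnc(-c3cccc(F)n3)n2)n(C2CCCCC2)n1`, differs from compound 3 in one place: 6-fluoropyridin-2-yl in place of 2-fluorophenyl on an aromatic carbon. Among the compounds with values here, none of the measured steps makes this kind of change. The steps of a 6.8-fold lower number from compound 1 to compound 2 (0.83 log units; beyond the scatter) and a 6.5-fold lower number from compound 1 to compound 3 (0.81 log units; beyond the scatter) exchange the whole halogen pattern on the ring, while the step of a 1.0-fold higher number from compound 2 to compound 3 (0.02 log units; within the scatter) moves a single fluorine and stays within the scatter. No step in this set replaces a ring carbon by a ring nitrogen, so there is no direct precedent, and the closest analogy, the small move from compound 2 to compound 3, gives no reason to expect more than a step within the scatter in this assay.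

Compound 4 is therefore expected to give about 250 nM in this assay, with a range from 80 nM to 800 nM. This estimate means a step of a 1.3-fold higher number from compound 3 to compound 4 (0.13 log units; within the scatter), expected to stay within the scatter.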

Compound 4, half-maximal effective concentration: > 3000 nM
Compound 4: only a limit was reported (the forecaster's own chance of this, stated with the estimate: 5%); middle value at least 12-fold (1.07 log units) away from the limit.
By their numbers in this assay, from the lowest: compounds 2 and 3 (each within the scatter of the next); then compound 1. At a limit, above all of these: compound 4.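

Until now, this aromatic carbon of a five-membered aromatic ring with 4 nitrogen had carried only carbon-only rings, and moving a single fluorine on such a ring made no difference beyond the scatter, with a 1.0-fold higher number from compound 2 to compound 3 (0.02 log units; within the scatter). Within the data shown here, compound 4 shows that the position is far less forgiving of a ring nitrogen, with its one hydrogen-bond acceptor, than of that fluorine move: the change to 6-fluoropyridin-2-yl gives an at least 16-fold higher number from compound 3 to compound 4 (1.20 log units; beyond the scatter) and an at least 16-fold higher number from compound 2 to compound 4 (1.22 log units; beyond the scatter), and even from 3,4-dichlorophenyl, the group with the highest number so far, it gives an at least 2.4-fold higher number from compound 1 to compound 4 (0.39 log units; beyond the scatter). The result for compound 4 in this assay is a limit and not a number, so the true size of these steps stays open: the limit of > 3000 nM in this assay, at which 1 of the 4 values shown sits.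

The compounds shown do not tell whether the ring nitrogen alone accounts for the loss or whether it depends on the fluorine that shares the ring. A plain pyridin-2-yl, or a 6-methoxypyridin-2-yl, at this position would begin to separate the two.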